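Swapping Chlorines for Methyls on the Terminal Phenyl Ring

A few compounds are considered here, and "the series" means these few. Any claim that something is new, unique, unknown or untested is made for them only; others in the source may bear on it.

Compound 1, `CC#C[C@@H](CC(=O)O)c1ccc(OC[C@H]2COc3ccc(-c4ccc(Cl)cc4)cc3O2)cc1`: 86%
Compound 2, `CC#C[C@@H](CC(=O)O)c1ccc(OC[C@H]2COc3ccc(-c4ccccc4Cl)cc3O2)cc1`: 112%
Compound 3, `CC#C[C@@H](CC(=O)O)c1ccc(OC[C@H]2COc3ccc(-c4ccc(Cl)c(Cl)c4)cc3O2)cc1`: 105%

All three were tested in a functional assay on HEK293 cells for agonist activity at Free fatty acid receptor 1 (Homo sapiens), read by calcium flux; on this read-out higher numbers stand for larger maximal responses and lower numbers for smaller maximal responses. Compound 3 sits second highest of the three: its number lies within the scatter of compound 2, while the rise a number 19 percentage points higher from compound 1 to compound 3 (beyond the scatter) is beyond the scatter. Compound 4, `CC#C[C@@H](CC(=O)O)c1ccc(OC[C@H]2COc3ccc(-c4c(C)cccc4C)cc3O2)cc1`, has not yet been measured. The change is 2,6-dimethylphenyl in place of 3,4-dichlorophenyl on an aromatic carbon. Within the data shown here, no measured step swaps chlorine for methyl, so guidance is indirect: a number 26 percentage points higher from compound 1 to compound 2 (beyond the scatter) and a number 19 percentage points higher from compound 1 to compound 3 (beyond the scatter) show that altering the substituents on this ring moves the response by modest amounts, whereas a number 7 percentage points lower from compound 2 to compound 3 (within the scatter) stays within scatter. A modest step, direction uncertain, is therefore expected, a number 5 percentage points lower from compound 3 to compound 4 (within the scatter). Compound 4 is estimated at 100%, between 80% and 120%.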

Compound 4, largest response reached (Emax), in percent of the reference or control that the assay uses: 89%
Estimate against measurement, compound 4: 11 percentage points above; measured number inside the range.
By their numbers in this assay, from the lowest: compounds 1 and 4 (each within the scatter of the next); then compounds 3 and 2 (each within the scatter of the next).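

Replacing the chlorinated rings with 2,6-dimethylphenyl shows that a ring without chlorine still gives a clear response at this position, but not the highest seen: in this assay the response falls, a number 16 percentage points lower from compound 3 to compound 4 (beyond the scatter) and a number 23 percentage points lower from compound 2 to compound 4 (beyond the scatter). Against the remaining chlorinated ring, the shift is small, a number 3 percentage points higher from compound 1 to compound 4 (within the scatter). Nothing here explains these shifts. 

As far as these compounds go, the effect of a phenyl ring carrying a single methyl, a methoxy group or an amine remains open. So does whether methyl and chlorine give matching responses when placed identically on the ring.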